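The source may report more compounds than this note shows. Statements on the series, on what has been measured and on what is new or still open speak of the compounds shown alone.

Measured so far in a functional assay on A549 cells (Homo sapiens) for antiproliferative activity, read by MTT assay, with a stated time of 72 h; a higher number here means a weaker inhibitor, a lower number a stronger inhibitor:

compound 1 `O=C(N/N=C/c1ccc(Br)cc1)Nc1ccc(Oc2ccnc3[nH]ccc23)c(F)c1`: 820 nM
compound 2 `O=C(N/N=C/c1ccc(F)cc1)Nc1ccc(Oc2ccnc3[nH]ccc23)c(F)c1`: 680 nM

Compound 1 stands highest of the two numbers in this assay; the nearest is compound 2 at 680 nM. Among the compounds with values here, the one step measured, a 1.2-fold lower number from compound 1 to compound 2 (0.08 log units; within the scatter), is a swap of the halogen on the aromatic carbon of the benzylidene ring and changes nothing beyond the scatter.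

Compound 3 `O=C(N/N=C/c1ccc([N+](=O)[O-])cc1)Nc1ccc(Oc2ccnc3[nH]ccc23)c(F)c1` differs from compound 1 at that same position: nitro in place of bromo on an aromatic carbon. Within the data shown here, the only measured step that bears on this change is a 1.2-fold lower number from compound 1 to compound 2 (0.08 log units; within the scatter), which also replaces the bromo at this carbon and stays within the scatter. No other substitution at this place has been measured, and nothing in the series shows how a group of this kind behaves here. On that basis no step beyond the scatter is expected in this assay; the expected step is a 1.0-fold lower number from compound 1 to compound 3 (0.01 log units; within the scatter).

Compound 3 is therefore estimated at 800 nM in this assay, within a range of 350 nM to 1800 nM.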

Compound 3, half-maximal inhibitory concentration: 20 nM
Beside the measured number, compound 3's estimate is 40-fold (1.60 log units) above it; measured number below the stated range.
By their numbers in this assay, from the lowest: compound 3; then compounds 2 and 1 (each within the scatter of the next).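

In this assay the 4-bromophenyl to 4-nitrophenyl change gives a 41-fold lower number from compound 1 to compound 3 (1.61 log units; beyond the scatter) and the fluoro to nitro change gives a 34-fold lower number from compound 2 to compound 3 (1.53 log units; beyond the scatter) in this series, so this aromatic carbon, para to a large group, is far from indifferent to what it carries. Within the data shown here, the flat halogen swap, a 1.2-fold lower number from compound 1 to compound 2 (0.08 log units; within the scatter) within the scatter, therefore describes only bromo and fluoro and not the position as a whole, and nitro, with its two hydrogen-bond acceptors and a double bond outside aromatic rings where bromo has none, is the first group here to move the number beyond the scatter. No measurement at hand accounts for this gain.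

On these data alone, whether the gain belongs to nitro alone, or would also appear with a nitrile, a trifluoromethyl group, an amine or a carboxylic acid on this carbon, remains open. Also open, as far as these compounds go, is whether nitro keeps this gain when the shared core is changed elsewhere, since all three compounds carry the same core.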